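This account rests on a few compounds, and the source may have more. Where it says the series, first, only, none or still open, it means among the compounds named here.

In an ADME assay for permeability, using PAMPA, at pH 7.4 (on this read-out higher numbers stand for higher permeability and lower numbers for lower permeability), compound 1 `CCc1ccc(NC(=O)Nc2cc(C)nc3ccccc23)cc1` gives 535 10^-6 cm/s while compound 2 `Cc1cc(NC(=O)Nc2ccc(C(F)(F)F)cc2)c2ccccc2n1` gives 2 10^-6 cm/s on the same scale. Compound 3 `Cc1cc(NC(=O)Nc2cccnc2)c2ccccc2n1` lies between these two at 63 10^-6 cm/s on that scale. Compound 4 `Cc1cc(NC(=O)Nc2ccc(N)cc2)c2ccccc2n1` carries 4-aminophenyl in place of pyridin-3-yl on an amide-type nitrogen and has not been measured. Among the measured compounds shown here, the only measured step is a 270-fold lower number from compound 1 to compound 2 (2.43 log units; beyond the scatter) for trifluoromethyl in place of ethyl on an aromatic carbon. It is large, yet it involves neither group of the present change, so it warns of wide swings without giving a direction. A step beyond the scatter is therefore not expected, and the step expected is a 1.3-fold higher number from compound 3 to compound 4 (0.10 log units; within the scatter) by this estimate. In this assay the estimate for compound 4 is 80 10^-6 cm/s with 15 10^-6 cm/s to 400 10^-6 cm/s as its expected range.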

Compound 4, apparent permeability: 530 10^-6 cm/s
For compound 4 the middle estimate is 6.6-fold (0.82 log units) below the measured one; the whole stated range lies below it.
By their numbers in this assay, from the lowest: compound 2; then compound 3; then compounds 4 and 1 (each within the scatter of the next).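

In this assay, 4-aminophenyl in place of pyridin-3-yl on the amide-type nitrogen brings an 8.4-fold higher number from compound 3 to compound 4 (0.92 log units; beyond the scatter) and so shows that this swap of one six-membered aromatic ring for another can matter. On the aromatic carbon, amino in place of trifluoromethyl brings a 270-fold higher number from compound 2 to compound 4 (2.42 log units; beyond the scatter) as a large step. Amino in place of ethyl brings a 1.0-fold lower number from compound 1 to compound 4 (0.00 log units; within the scatter) and leaves those two groups indistinguishable here.

On these data alone, whether hydroxyl, methoxy or dimethylamino on that carbon would match amino and ethyl stays open. No measurement shown explains any of these steps.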